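Lengthening the Tail Chain on the Amide Side

A few compounds are considered here, and "the series" means these few. Any claim that something is new, unique, unknown or untested is made for them only; others in the source may bear on it.

Three compounds share one core and differ only in a tail attached to a benzene ring. Compound 1 `CN(C)C(=O)c1cc2cnc(Nc3ccc(S(=O)(=O)NCCCN=C=S)cc3)nc2n1C1CCCC1` and compound 2 `CN(C)C(=O)c1cc2cnc(Nc3ccc(S(=O)(=O)NCCCCN=C=S)cc3)nc2n1C1CCCC1` carry that tail through a sulfonamide nitrogen, while compound 3 `CN(C)C(=O)c1cc2cnc(Nc3ccc(NC(=O)CCCN=C=S)cc3)nc2n1C1CCCC1` carries it through an amide carbonyl. In a functional assay on A549 cells (Homo sapiens) for inhibition, read by CCK-8 assay, with a stated time of 72 h, tested at 10 uM (a lower number here means a weaker effect, a higher number a stronger effect of the compound at the concentration tested), compound 1 gives 102%, compound 2 gives 101% and compound 3 gives 102%. Compound 3 thus stands level with compound 1 at the digits shown, the two together the highest of the three numbers, and its step from compound 2 is a number 1 percentage points higher from compound 2 to compound 3 (within the scatter), within the scatter.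

Compound 4 `CN(C)C(=O)c1cc2cnc(Nc3ccc(NC(=O)CCCCN=C=S)cc3)nc2n1C1CCCC1` has not yet been measured. It differs from compound 3 in one place: a group of 4 heavy atoms (2 carbon, 1 nitrogen, 1 sulfur; no ring) in place of a group of 3 heavy atoms (1 carbon, 1 nitrogen, 1 sulfur; no ring), on a saturated chain carbon, three bonds along the chain from a carbonyl carbon. The same lengthening of the chain on the sulfonamide side gave a number 1 percentage points lower from compound 1 to compound 2 (within the scatter), within the scatter, and exchanging the whole tail gave no change at the digits printed from compound 1 to compound 3 (within the scatter). The expected step is therefore none beyond the scatter, a number 1 percentage points lower from compound 3 to compound 4 (within the scatter). Compound 4 is estimated at 101%, with a range from 92% to 108%.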

Compound 4, a percentage reported as inhibition, at one concentration (the size of the read-out at that concentration, not a potency): 102%
For compound 4 the middle estimate is 1 percentage points below the measured one; measured number inside the range.
By their numbers in this assay, from the lowest: compounds 2, 1, 3 and 4 (each within the scatter of the next).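

Lengthening the tail on the amide side, with the group of 4 heavy atoms in place of the group of 3 heavy atoms, leaves the read-out in this assay unmoved, with no change at the digits printed from compound 3 to compound 4 (within the scatter). This saturated chain position therefore accepts the longer tail on the amide side too, and compound 4 also shows no step beyond the scatter against the sulfonamide-linked tails, with a number 1 percentage points higher from compound 2 to compound 4 (within the scatter) and no change at the digits printed from compound 1 to compound 4 (within the scatter). The same lengthening has now been read on both linkers, and the two steps agree: the same change on two cores in this assay, a number 1 percentage points lower (within the scatter) from compound 1 to compound 2 and no change at the digits printed (within the scatter) from compound 3 to compound 4, 1 percentage points apart, within the scatter of two such steps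

A read-out at one concentration is not a potency, so these numbers cannot rank the four tails by strength. From the compounds shown here alone, whether a still longer chain, or an amine in place of the tail, would hold the number at this level remains open.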